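Trimming a Methyl from the Amine of Compound 2

The compounds below may be only part of what the source reports. "The series", "measured", "known", "first", "only" and "open" are said of these compounds alone.

Measured compounds:
compound 1, `C=C=CCN(C)Cc1ccccc1`: 8200 nM
compound 2, `C=C=C(Cc1ccccc1)CN(C)C`: 25000 nM
compound 3, `C=C=C(CN)Cc1ccc(C)cc1`: 1100 nM

In an assay on isolated protein for inhibition of Monoamine oxidase (Rattus norvegicus) (a higher number here means a weaker inhibitor, a lower number a stronger inhibitor), compound 2 gives 25000 nM, the highest of the three numbers, so it is the weakest inhibitor of the set. The nearest neighbour on the scale is compound 1 with 8200 nM, a gap beyond the usual scatter, and the furthest is compound 3 with 1100 nM, a much larger gap. No pair among these three differs in only one place, so none of them shows directly what a single change is worth.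

Compound 4, `C=C=C(CNC)Cc1ccccc1`, has not yet been tested in this assay. It differs from compound 2 in one spot: hydrogen in place of methyl on an amine nitrogen. In words, a hydrogen takes the place of a methyl on the amine nitrogen, so the dimethylamino group becomes a methylamino group.

Since compound 2 stands weakest, and the other two compounds carry fewer carbons on their nitrogen, a modest gain in potency is the expectation for compound 4, a step of roughly a 4.2-fold lower number from compound 2 to compound 4 (0.62 log units; beyond the scatter), though a change within the scatter cannot be excluded. The estimate for compound 4 in this assay is 6000 nM, within a range from 1500 nM to 20000 nM.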

Compound 4, half-maximal inhibitory concentration: 6200 nM
Compound 4: middle estimate off by 1.0-fold (0.01 log units), on the low side, and the stated range covers the measured number.
By their numbers in this assay, from the lowest: compound 3; then compounds 4 and 1 (each within the scatter of the next); then compound 2.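

In this assay, going by these compounds alone, the change from dimethylamino to methylamino gives a 4.0-fold lower number from compound 2 to compound 4 (0.61 log units; beyond the scatter), and this is the first comparison in the set that isolates a single change. It shows that the amine nitrogen responds to a small edit: swapping one methyl for a hydrogen, a loss of just one carbon, moves the number beyond the usual scatter and gives a stronger inhibitor. The second methyl on this nitrogen is therefore not needed for inhibition in this pair, although nothing measured here explains why the step goes this way.

From the compounds shown here alone, it remains open whether the trend continues if the remaining methyl of compound 4 also gives way to hydrogen, leaving a free primary amine on the same core, a question compound 3 cannot settle because it differs from compound 4 in more than one place. Also open, going by these compounds, is how this nitrogen would respond to an ethyl or a cyclopropyl group in place of that methyl, which would show whether the step depends on the methyl itself or extends to other carbon groups.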